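Replacing a fluoroethoxy tail with methylsulfanyl at a carbonyl

This account rests on a few compounds, and the source may have more. Where it says the series, first, only, none or still open, it means among the compounds named here.

Two compounds share one core and differ only in the group attached to the carbonyl of the ring nitrogen. Compound 1 `COC(=O)N1CCC(Oc2ncnc3c2CCN3c2ccc(S(C)(=O)=O)cc2F)CC1` gives in a functional assay on CHO-K1 cells with Glucose-dependent insulinotropic receptor (Homo sapiens) as the target, read by a luciferase reporter, with a stated time of 5 h (a lower number here means a smaller maximal response, a higher number a larger maximal response), a maximal response of 119%. Among the measured compounds shown here, compound 2 `CS(=O)(=O)c1ccc(N2CCc3c(OC4CCN(C(=O)OCCF)CC4)ncnc32)c(F)c1` gives in this assay a maximal response of 86%, which is the lowest of the two numbers measured so far. For the measured compounds named here, the one measured step is a number 33 percentage points lower from compound 1 to compound 2 (beyond the scatter), a large drop that sits at the same end of the molecule.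

Compound 3 `CSC(=O)N1CCC(Oc2ncnc3c2CCN3c2ccc(S(C)(=O)=O)cc2F)CC1` carries the change (methylsulfanyl in place of 2-fluoroethoxy on a carbonyl carbon). Going by the values given here, the fluorine-bearing chain that accompanied the drop is removed, and a small group roughly the size of the one in compound 1 takes its place, though oxygen is exchanged for sulfur at the same time, a swap for which no measured step exists. On the strength of the step from compound 1 to compound 2 alone, a rise back toward the value of compound 1 is expected, but with wide uncertainty. Compound 3 is therefore estimated to give 105%, within 85% to 125%. This estimate means that a number 19 percentage points higher from compound 2 to compound 3 (beyond the scatter) is expected.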

Compound 3, largest response reached (reported as percent of maximum), in percent of the reference or control that the assay uses: 135%
The estimate for compound 3 lay 30 percentage points below the measured number; the whole stated range lies below it.
By their numbers in this assay, from the lowest: compound 2; then compound 1; then compound 3.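

The carbonyl position can do more than recover from the drop seen with compound 2. In this assay, exchanging 2-fluoroethoxy for methylsulfanyl gives a number 49 percentage points higher from compound 2 to compound 3 (beyond the scatter) and so more than undoes the earlier loss, which leaves compound 3 with the largest maximal response of the three. Among the compounds shown here, the comparison with the methoxy group is the more telling one, since it shows a number 16 percentage points higher from compound 1 to compound 3 (beyond the scatter) and thus that a group on this carbonyl carbon can lift the response past that of compound 1, whereas the only earlier step went down; nothing at hand explains why the sulfur-linked group reads this way.

As far as these compounds go, whether the gain stays when the chain on sulfur grows, as in ethylsulfanyl or 2-fluoroethylsulfanyl, remains open, and the second of these would also show whether the fluorine-bearing chain lowers the response with sulfur as it did with oxygen. From the compounds shown here alone, it is equally open how an amine such as dimethylamino, placed on the same carbonyl carbon, would compare with methylsulfanyl and methoxy.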